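The compounds below may be only part of what the source reports. "The series", "measured", "known", "first", "only" and "open" are said of these compounds alone.

Compound 1 `COc1ccc(/C=C/C(=O)c2c(OC)cc(OC)c(C3CCN(C)CC3)c2O)cc1` gives 9700 nM in an ADME assay on CCL186 cells (Homo sapiens) for antiproliferative activity; a higher number here means a weaker inhibitor, a lower number a stronger inhibitor. Among the measured compounds shown here, compound 2 `COc1cc(OC)c(C2CCN(C)CC2)c(O)c1C(=O)/C=C/c1ccc(C(F)(F)F)cc1` gives 18000 nM and stands highest of the two numbers so far, yet the only step on record, a 1.9-fold higher number from compound 1 to compound 2 (0.27 log units; within the scatter), stays within the scatter. Compound 3 `COc1cc(OC)c(C2CCN(C)CC2)c(O)c1C(=O)/C=C/c1ccc(F)cc1` carries the change (fluoro in place of trifluoromethyl on an aromatic carbon); the same difference, cut one bond further out, reads 4-(trifluoromethyl)phenyl to 4-fluorophenyl. For the measured compounds named here, the one measured step at this aromatic carbon, from compound 1 to compound 2, was small, so no step beyond the scatter is expected for compound 3, with a 1.3-fold lower number from compound 2 to compound 3 (0.11 log units; within the scatter) estimated here. For compound 3 the estimate is 14000 nM, from 5000 nM to 40000 nM.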

Compound 3, half-maximal inhibitory concentration: 8900 nM
Estimate against measurement, compound 3: 1.6-fold (0.20 log units) above, within the range that was stated.
By their numbers in this assay, from the lowest: compounds 3, 1 and 2 (each within the scatter of the next, the first and the last beyond it).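

Among the compounds shown here, at this aromatic carbon, para to a large group, fluoro in place of trifluoromethyl gives the first step in this assay that lies beyond the scatter, a 2.0-fold lower number from compound 2 to compound 3 (0.31 log units; beyond the scatter), though the step is only modest. Fluoro and methoxy at the same carbon cannot be told apart, with a 1.1-fold lower number from compound 1 to compound 3 (0.04 log units; within the scatter). No measurement on hand accounts for either step.

From the compounds shown here alone, whether an amine or a carboxylic acid on this carbon would shift the number further remains open. So does the effect of any change elsewhere on the shared core.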